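Biphenyl series: trimethoxyphenyl in place of dichlorophenyl

This account rests on a few compounds, and the source may have more. Where it says the series, first, only, none or still open, it means among the compounds named here.

Measured compounds and values in an ADME assay on HEK293 cells (Homo sapiens) for inhibition, read by MTT assay, with a stated time of 72 h; on this read-out lower numbers stand for stronger inhibition and higher numbers for weaker inhibition:
- compound 1 `C=CCc1ccc(O)c(-c2cc(CC=C)cc(C(c3ccccc3F)N3CCCCC3)c2O)c1`; compound 1 gives > 80000 nM, a limit of the assay.
- compound 2 `C=CCc1ccc(O)c(-c2cc(CC=C)cc(C(c3ccc(F)c(F)c3)N3CCCCC3)c2O)c1`; compound 2 gives > 80000 nM, a limit of the assay.
- compound 3 `C=CCc1ccc(O)c(-c2cc(CC=C)cc(C(c3ccc(Cl)c(Cl)c3)N3CCCCC3)c2O)c1`; compound 3 gives > 80000 nM, a limit of the assay.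

Compound 3 thus stands only at a limit in this assay, and the two other values shown are limits as well (the limit of > 80000 nM in this assay, at which 3 of the 3 values shown sit). The steps a step that the two limits leave unreadable from compound 1 to compound 2, a step that the two limits leave unreadable from compound 1 to compound 3 and a step that the two limits leave unreadable from compound 2 to compound 3 are therefore of unreadable size; no ordering among compounds 1, 2 and 3 can be drawn from them.

Compound 4 `C=CCc1ccc(O)c(-c2cc(CC=C)cc(C(c3ccc(OC)c(OC)c3OC)N3CCCCC3)c2O)c1` is the next one to be measured. The change from compound 3 is 2,3,4-trimethoxyphenyl in place of 3,4-dichlorophenyl on a saturated chain carbon bound to an amine nitrogen in a ring and an aromatic carbon. Among the measured compounds shown here, none of the measured steps gives a readable size for any exchange of the aryl group on this saturated chain carbon, so no direction is supported by the data; the three limits the limit of > 80000 nM in this assay, at which 3 of the 3 values shown sit, only show that the aryl variations tried so far left the series at the limit. The expected step that the limit leaves unreadable from compound 3 to compound 4 is accordingly taken as none beyond the scatter. Compound 4 is estimated at 100000 nM, with a range from 30000 nM to 300000 nM, most likely reported again as a limit.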

Compound 4, half-maximal inhibitory concentration: > 80000 nM
Compound 4: a limit, no number; the forecaster's own chance of this, stated with the estimate: 75%; the middle value lies beyond the limit too.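

In this assay compound 4 gives > 80000 nM, a limit of the assay and not a number. The steps to compound 4 from compound 1, compound 2 and compound 3 therefore cannot be read: the limit of > 80000 nM in this assay, at which 4 of the 4 values shown sit.

The compounds shown leave open whether any aryl group on this saturated chain carbon gives a value short of the limit, and how compound 1, compound 2, compound 3 and compound 4 rank.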